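The compounds below may be only part of what the source reports. "The series", "measured", "known", "first", "only" and "open" are said of these compounds alone.

Going by the values given here, in an ADME assay on NCI-H460 cells (Homo sapiens) for cytotoxicity, read by sulforhodamine B assay, with a stated time of 48 h (on this read-out lower numbers stand for higher toxicity in this test and higher numbers for lower toxicity in this test), compound 1 `O=C1/C(=C/c2ccc3ccccc3c2)CNC/C1=C\c1ccc2ccccc2c1` gives 98300 nM, the only true number available so far. Compound 2 `O=C1/C(=C/c2ccc3[nH]ccc3c2)CNC/C1=C\c1ccc2[nH]ccc2c1` reports > 100000 nM in this assay, which is a limit of the test and not a number. Compound 3 `O=C1/C(=C/c2ccc(OCc3ccc(Br)cc3)cc2)CNC/C1=C\c1ccc(OCc2ccc(Br)cc2)cc1` reports > 100000 nM, again a limit and not a number. Among the compounds with values here, the series so far is therefore defined by the limit of > 100000 nM in this assay, at which 2 of the 3 values shown sit, which leaves compound 1 as the single measured point, and its place relative to the other two cannot be told.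

The next compound to be tested, compound 4 `C=CC(=O)N1C/C(=C\c2ccc3ccccc3c2)C(=O)/C(=C/c2ccc3ccccc3c2)C1`, keeps the core of compound 1 and changes it in one place: vinylcarbonyl in place of hydrogen on an amine nitrogen in a ring. In plain terms, vinylcarbonyl stands in place of hydrogen on an amine nitrogen in a ring. Within the data shown here, no two measured compounds differ in just one place, so no measured step can serve as a guide, and the expectation rests on this structural change alone. A clear step beyond the usual scatter is expected, towards lower numbers, which here would mean higher toxicity. The estimated change is a 4.9-fold lower number from compound 1 to compound 4 (0.69 log units; beyond the scatter) in this assay. For compound 4 the expected value is 20000 nM, with an estimated range from 3000 nM to 100000 nM.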

Compound 4, concentration lethal to 50% of the cells: 9800 nM
The estimate for compound 4 lay 2.0-fold (0.31 log units) above the measured number, within the range that was stated.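

Going by these compounds alone, putting vinylcarbonyl in place of hydrogen on an amine nitrogen in a ring gives a 10-fold lower number from compound 1 to compound 4 (1.00 log units; beyond the scatter) in this assay, the first measured step and one that lies beyond the usual scatter. On this read-out a lower number stands for higher toxicity in this test, so the ring nitrogen, which carries hydrogen in all three earlier compounds, proves to be a place where a single change can shift the result. Compound 2 and compound 3 could not show this, as each differs from compound 1 elsewhere in the structure, and much of the series rests on a limit of the test and not on a number: the limit of > 100000 nM in this assay, at which 2 of the 4 values shown sit.

An acetyl or a propanoyl group on the same nitrogen would show whether the carbonyl alone goes with this step or whether the vinyl part is needed as well. On these data alone, whether vinylcarbonyl on the nitrogen of compound 2 or compound 3 would also give a lower number remains open, and a single step establishes no pattern across the series.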